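Swapping one chain for another on a shared core

This account rests on a few compounds, and the source may have more. Where it says the series, first, only, none or still open, it means among the compounds named here.

In an ADME assay for permeability, using PAMPA, at pH 4 (on this read-out lower numbers stand for lower permeability and higher numbers for higher permeability), the measured compounds read as follows
Compound 1 `COc1cc2[nH]c(C)c(C)c(=O)c2cc1Cl` gives 37 10^-6 cm/s
Compound 2 `COc1cc2[nH]c(C)c(Br)c(=O)c2cc1Cl` gives 125 10^-6 cm/s
Compound 3 `CCCCC#Cc1c(C)[nH]c2cc(OC)c(Cl)cc2c1=O` gives 148 10^-6 cm/s

The top of this small set is shared (a 1.2-fold higher number from compound 2 to compound 3 (0.07 log units; within the scatter)), and the low end stands apart (a 4.0-fold higher number from compound 1 to compound 3 (0.60 log units; beyond the scatter)). Compound 4 `CCCCC/C=C/c1c(C)[nH]c2cc(OC)c(Cl)cc2c1=O` carries one change (hept-1-en-1-yl in place of hex-1-yn-1-yl on an aromatic carbon), hept-1-en-1-yl in place of hex-1-yn-1-yl on an aromatic carbon. For the measured compounds named here, no measured step swaps one chain for another. The closest evidence is bromo giving way to hex-1-yn-1-yl (a 1.2-fold higher number from compound 2 to compound 3 (0.07 log units; within the scatter)), while the step from methyl to bromo was modest (a 3.4-fold higher number from compound 1 to compound 2 (0.53 log units; beyond the scatter)). In this assay no step beyond the scatter is therefore expected. The estimate means an expected step (a 1.1-fold lower number from compound 3 to compound 4 (0.06 log units; within the scatter)) inside the scatter. Compound 4 is estimated at 130 10^-6 cm/s (expected range 55 10^-6 cm/s to 300 10^-6 cm/s).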

Compound 4, apparent permeability: 280 10^-6 cm/s
Beside the measured number, compound 4's estimate is 2.2-fold (0.33 log units) below it, and the stated range covers the measured number.
By their numbers in this assay, from the lowest: compound 1; then compounds 2, 3 and 4 (each within the scatter of the next, the first and the last beyond it).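

In this assay, for the compounds shown here, this is the first swap of one chain for another on this aromatic carbon, and it leaves hex-1-yn-1-yl and hept-1-en-1-yl unresolved (a 1.9-fold higher number from compound 3 to compound 4 (0.28 log units; within the scatter)). Hept-1-en-1-yl, unlike hex-1-yn-1-yl, also stands apart from bromo (a 2.2-fold higher number from compound 2 to compound 4 (0.35 log units; beyond the scatter)), and it stands apart from methyl as well (a 7.6-fold higher number from compound 1 to compound 4 (0.88 log units; beyond the scatter)). Nothing measured here gives a reason for these steps.

This change replaces a triple bond with a double bond and lengthens the chain together, and the compounds shown do not separate the two. As far as these compounds go, how a shorter chain, or a chain ending in an amine or a carboxylic acid, would read on this carbon stays open.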